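The source may report more compounds than this note shows. Statements on the series, on what has been measured and on what is new or still open speak of the compounds shown alone.

Measured so far in an assay on CHO cells for displacement of a labelled ligand from adenosine receptor A3 (Homo sapiens), read by scintillation counting, with a stated time of 60 min; on this read-out lower numbers stand for stronger inhibition and higher numbers for weaker inhibition:
compound 1 `COc1cccc(CCC(=O)Nc2nc3ccccc3c(=O)s2)c1`: 173 nM
compound 2 `O=C(CCCc1ccc(Cl)c(Cl)c1)Nc1nc2ccccc2c(=O)s1`: a limit of the assay, > 1000 nM
compound 3 `COc1cccc(CCCC(=O)Nc2nc3ccccc3c(=O)s2)c1`: 382 nM

Compound 1 gives the lowest of the two numbers; compound 3 sits higher, by a gap beyond the scatter. The value of compound 2 is a limit of > 1000 nM in this assay, at which 1 of the 3 values shown sits, and not a number. Compound 4 `O=C(CCc1ccc(Cl)c(Cl)c1)Nc1nc2ccccc2c(=O)s1` has not been measured; it differs from compound 1 by 3,4-dichlorophenyl in place of 3-methoxyphenyl on a saturated chain carbon, two bonds along the chain from a carbonyl carbon. Going by the values given here, the one measured step that bears on this is an at least 2.6-fold lower number from compound 2 to compound 3 (0.41 log units; beyond the scatter), the same swap run the other way, on a chain carbon three bonds along the chain from a carbonyl carbon rather than two. Reversing it, compound 4 is expected to give a higher number than compound 1, by roughly a 3.5-fold higher number from compound 1 to compound 4 (0.54 log units; beyond the scatter). The estimate for compound 4 is 600 nM, ranging from 250 nM to 1500 nM.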

Compound 4, inhibition constant: > 1000 nM
Compound 4 was reported as a limit (the forecaster's own chance of this, stated with the estimate: 35%); middle value at least 1.6-fold (0.22 log units) away from the limit.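

In this assay, placing 3,4-dichlorophenyl in the position of 3-methoxyphenyl on the shorter chain gives an at least 5.7-fold higher number from compound 1 to compound 4 (0.76 log units; beyond the scatter). Compound 4 gives > 1000 nM, a limit of the assay and not a number. The 3-methoxyphenyl group therefore gives the lower number on both chains shown: the same change on two cores in this assay, an at least 2.6-fold lower number (0.41 log units; beyond the scatter) from compound 2 to compound 3 and an at least 5.7-fold lower number (0.76 log units; beyond the scatter) from compound 4 to compound 1; the limit leaves it open whether they differ

The limits leave open how far the two 3,4-dichlorophenyl compounds differ from each other, so chain length cannot be judged for that group. Also open, on these data alone, is whether a single chlorine, a hydroxyl or an amine on the phenyl ring would give a lower number.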